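This account rests on a few compounds, and the source may have more. Where it says the series, first, only, none or still open, it means among the compounds named here.

Measured so far in an assay on a protein complex for binding affinity to Neuronal acetylcholine receptor; alpha4/beta2 (Rattus norvegicus); on this read-out lower numbers stand for stronger inhibition and higher numbers for weaker inhibition:

compound 1, `CN1CCC[C@H]1COc1cncc(C#CC(C)(C)O)c1`, 2.9 nM
compound 2, `C#Cc1cncc(OC[C@@H]2CCCN2C)c1`, 1.6 nM

Going by the values given here, compound 2 gives the lowest of the two numbers in this assay, but its only neighbour, compound 1, lies within the scatter of it: the step of a 1.8-fold lower number from compound 1 to compound 2 (0.26 log units; within the scatter) is not a real difference. So the two values show that a substituent on the triple-bonded carbon can be added or removed without a change that exceeds the scatter.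

Compound 3, `CN1CCC[C@H]1COc1cncc(C#Cc2ccccc2)c1`, is not yet measured in this assay. It differs from compound 2 by phenyl in place of hydrogen on a triple-bonded carbon. Among the compounds with values here, the one measured step that bears on this change is a 1.8-fold lower number from compound 1 to compound 2 (0.26 log units; within the scatter), which concerns the same triple-bonded carbon and stays within the scatter. Nothing measured here tells how a ring in that place, rather than the 1-hydroxy-1-methylethyl group, is tolerated. On the evidence of that one step the expected change in this assay for compound 3 is small, with no clear direction, and the estimated step is a 1.9-fold higher number from compound 2 to compound 3 (0.27 log units; within the scatter). Compound 3 is therefore expected to give about 3 nM in this assay, with a range from 0.8 nM to 15 nM.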

Compound 3, inhibition constant: 0.51 nM
The estimate for compound 3 lay 5.9-fold (0.77 log units) above the measured number; the measured number lies below the stated range.
By their numbers in this assay, from the lowest: compound 3; then compounds 2 and 1 (each within the scatter of the next).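

In this assay, the triple-bonded carbon proves sensitive to what it carries: phenyl in place of hydrogen gives a 3.1-fold lower number from compound 2 to compound 3 (0.50 log units; beyond the scatter) and phenyl in place of 1-hydroxy-1-methylethyl gives a 5.7-fold lower number from compound 1 to compound 3 (0.75 log units; beyond the scatter), both modest but beyond the scatter. The earlier pair showed only that hydrogen and 1-hydroxy-1-methylethyl could be exchanged there without a change beyond the scatter, so it gave no sign that a substituent at this carbon could move the number at all. Phenyl, with its 6 heavy atoms and six-membered aromatic ring of carbon only, is therefore accepted at this place, and it separates from both of the other two groups in the direction of a lower number.

Whether the ring itself matters, or only the size of the group, stays open, since the compounds shown include no cyclohexyl, no pyridine ring, no substituted phenyl such as 4-fluorophenyl, no amine and no longer alkyl chain on this carbon. No measurement in hand speaks to why phenyl differs from the other two groups.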